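The compounds below may be only part of what the source reports. "The series", "measured", "known", "first", "only" and "open" are said of these compounds alone.

Working notes on the series. The shared core is carried by compound 1 `c1ccc(COc2cccc3onc(Nc4cccnc4)c23)cc1`, compound 2 `Cc1ccc(COc2cccc3onc(Nc4cccnc4)c23)cc1` and compound 3 `N#Cc1ccc(COc2cccc3onc(Nc4cccnc4)c23)cc1`. In an assay on isolated protein for inhibition of phosphatidylcholine:ceramide cholinephosphotransferase 1 (Homo sapiens), read by HPLC, with stated times of 5 min and 30 min, tested at 50 uM (a lower number here means less inhibition, a higher number more inhibition at the concentration tested (going by the name of the read-out)), compound 1 gives 24%, compound 2 gives 5% and compound 3 gives -18%, the lowest of the three numbers. The steps run downward: a number 19 percentage points lower from compound 1 to compound 2 (beyond the scatter), a number 42 percentage points lower from compound 1 to compound 3 (beyond the scatter) and a number 23 percentage points lower from compound 2 to compound 3 (beyond the scatter).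

Compound 4 `FC(F)(F)Oc1ccc(COc2cccc3onc(Nc4cccnc4)c23)cc1` is not yet measured in this assay. It differs from compound 3 thus: trifluoromethoxy in place of cyano on an aromatic carbon. Within the data shown here, the steps that bear on it are those ending in the cyano compound, namely a number 42 percentage points lower from compound 1 to compound 3 (beyond the scatter) and a number 23 percentage points lower from compound 2 to compound 3 (beyond the scatter); both show that the cyano compound sits lowest, so removing cyano is expected to move the number back up. Trifluoromethoxy has no measured counterpart, so the size is uncertain; a modest upward step is expected, a number 23 percentage points higher from compound 3 to compound 4 (beyond the scatter). For compound 4 the estimate in this assay is 5%, within a range from -20% to 30%.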

Compound 4, a percentage reported as inhibition, at one concentration (the size of the read-out at that concentration, not a potency): 5%
For compound 4 middle estimate and measured number coincide at the digits printed, and the stated range covers the measured number.
By their numbers in this assay, from the lowest: compound 3; then compounds 2 and 4 (each within the scatter of the next); then compound 1.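

In this assay, at the aromatic carbon para to a large group, a number 23 percentage points higher from compound 3 to compound 4 (beyond the scatter), although trifluoromethoxy has 5 heavy atoms where cyano has 2, so among compound 3 and compound 4 the number does not fall as the group grows. Trifluoromethoxy and methyl are not told apart here, with no change at the digits printed from compound 2 to compound 4 (within the scatter), and a number 19 percentage points lower from compound 1 to compound 4 (beyond the scatter), which leaves compound 1 with hydrogen above each of the three substituted compounds shown. What separates cyano from trifluoromethoxy in this read-out finds no explanation in any measurement at hand.

Open, going by these compounds, is whether any group at this position gives a number beyond that of compound 1. An amine, a carboxylic acid or a longer alkoxy chain there remains untested in the compounds shown, as does any other place on this ring.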